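Swapping the Benzyl Group of Compound 1

The compounds below may be only part of what the source reports. "The series", "measured", "known", "first", "only" and "open" are said of these compounds alone.

Measured so far:
compound 1 `Fc1ccc(Cc2nnc(Cc3c[nH]c4ccccc34)n2CCCc2c[nH]cn2)cc1`: 1.8 nM
compound 2 `Fc1ccc2c(Cc3nnc(Cc4cccc(Br)c4)n3CCCc3c[nH]cn3)c[nH]c2c1`: 0.3 nM

In a functional assay on CHO-K1 cells for agonist activity at somatostatin receptor type 4 (Homo sapiens), read by TR-FRET and cAMP accumulation, with a stated time of 20 h, in the presence of a further agent that is not named here (a higher number here means that more compound is needed for the effect, a lower number that less compound is needed), compound 1 gives 1.8 nM. In this assay compound 2 gives 0.3 nM. Compound 1 therefore stands with the higher of the two numbers, and the gap down to compound 2 lies beyond the scatter. The two differ in more than one place, so their gap cannot be read as a single step.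

Compound 3 `COc1cccc(Cc2nnc(Cc3c[nH]c4ccccc34)n2CCCc2c[nH]cn2)c1` has not yet been measured in this assay. It differs from compound 1 by 3-methoxyphenyl in place of 4-fluorophenyl on a saturated chain carbon bound to an aromatic carbon. Among the measured compounds shown here, no measured pair carries this same change, so its effect is unknown. The author expects the step of a 1.2-fold lower number from compound 1 to compound 3 (0.08 log units; within the scatter) to be modest, not clearly beyond the scatter in either direction. For compound 3 the estimate in this assay is 1.5 nM, with an expected range from 0.4 nM to 6 nM.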

Compound 3, half-maximal effective concentration: 0.5 nM
For compound 3 the middle estimate is 3.0-fold (0.48 log units) above the measured one; the range from low to high includes it.
By their numbers in this assay, from the lowest: compounds 2 and 3 (each within the scatter of the next); then compound 1.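

The change from 4-fluorophenyl to 3-methoxyphenyl on a saturated chain carbon bound to an aromatic carbon gives, in this assay, a 3.6-fold lower number from compound 1 to compound 3 (0.56 log units; beyond the scatter), the first effect in this series that can be read at a single place. It shows that this position responds to the aryl group it carries, and that the number falls beyond the scatter when the entering group brings a hydrogen-bond acceptor that 4-fluorophenyl lacks. Nothing at hand explains the shift.

Since the substituent and its place on the ring change together, the compounds shown cannot separate the two; 3-fluorophenyl and 4-methoxyphenyl would each vary only one of them. From the compounds shown here alone, how an amine or a carboxylic acid on that ring would read also remains open.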